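A few compounds are considered here, and "the series" means these few. Any claim that something is new, unique, unknown or untested is made for them only; others in the source may bear on it.

In a functional assay on KM12 cells (Homo sapiens) for antiproliferative activity (on this read-out higher numbers stand for weaker inhibition of growth and lower numbers for stronger inhibition of growth), compound 1 `COc1ccc(-c2nc3cc(F)ccc3s2)cc1F` gives 20600 nM, compound 2 `COc1ccc(-c2nc3cc(F)ccc3s2)cc1Cl` gives 7050 nM and compound 3 `COc1ccc(-c2nc3cc(F)ccc3s2)cc1Br` gives 6700 nM. Compound 3 thus stands level with compound 2, and both lie clearly below compound 1. Compound 4 `COc1ccc(-c2nc3cc(F)ccc3s2)cc1I` carries iodo in place of bromo on an aromatic carbon, ortho to a methoxy group (iodo in place of bromo on an aromatic carbon). Among the measured compounds shown here, replacing fluoro gave modest steps, a 2.9-fold lower number from compound 1 to compound 2 (0.47 log units; beyond the scatter) and a 3.1-fold lower number from compound 1 to compound 3 (0.49 log units; beyond the scatter), but the closest precedent, bromo in place of chloro, gave only a 1.1-fold lower number from compound 2 to compound 3 (0.02 log units; within the scatter). On that precedent, no step beyond the scatter is expected in this assay. The expected step is a 1.1-fold lower number from compound 3 to compound 4 (0.05 log units; within the scatter). Compound 4 is estimated at 6000 nM, within an expected range of 2500 nM to 14000 nM.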

Compound 4, concentration for 50% growth inhibition: 6900 nM
Beside the measured number, compound 4's estimate is 1.2-fold (0.06 log units) below it; the measured number falls inside the stated range.
By their numbers in this assay, from the lowest: compounds 3, 4 and 2 (each within the scatter of the next); then compound 1.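

In this assay iodo at this position, ortho to a methoxy group, matches bromo with a 1.0-fold higher number from compound 3 to compound 4 (0.01 log units; within the scatter) and matches chloro with a 1.0-fold lower number from compound 2 to compound 4 (0.01 log units; within the scatter) and keeps the gap to fluoro with a 3.0-fold lower number from compound 1 to compound 4 (0.48 log units; beyond the scatter). The level shared by chloro and bromo thus holds for a third halogen, and among the four halogens shown only fluoro stands apart. Nothing available explains this flat stretch. The compounds shown leave open whether a non-halogen group here, such as an amine, a nitrile or a carboxylic acid, would depart from this level.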